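Furan for Thiophene in a Small Set of Inhibitors

The source may hold more compounds than are shown below. What is called first, only, known or untested is meant among the compounds shown, and "the series" means these compounds.

Compound 1, `CCOC(=O)c1cnn(-c2nc(-c3ccco3)c(C#N)c(=O)n2C)c1N`, gives 108 ug/mL in a functional assay, with a stated time of 150 min; on this read-out higher numbers stand for weaker inhibition and lower numbers for stronger inhibition.
Compound 2, `Cn1c(NN)nc(-c2cccs2)c(C#N)c1=O`, gives 63 ug/mL in this assay.
Compound 3, `CCOC(=O)c1cnn(-c2nc(-c3cccs3)c(C#N)c(=O)n2C)c1N`, gives 98 ug/mL in this assay.

Compounds 3 and 1 share one core and differ in a single place: furan-2-yl in place of thiophen-2-yl on an aromatic carbon. The step this change made is a 1.1-fold higher number from compound 3 to compound 1 (0.04 log units; within the scatter), so the two values cannot be told apart. Compound 2 carries a different core, and the difference between the two cores is not broken down here. Its value and those of compounds 3 and 1 all lie within the scatter of one another, so no order among the three can be claimed.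

Compound 4, `Cn1c(NN)nc(-c2ccco2)c(C#N)c1=O`, has not yet been measured. It stands to compound 2 as compound 1 stands to compound 3: furan-2-yl in place of thiophen-2-yl on an aromatic carbon. The surroundings are not identical, since in compound 2 the position is meta to an aminoamino group (2 heavy atoms) whereas in compound 3 it is meta to a large group, so this is the same kind of change rather than the same change. Going by the values given here, the only guide is the earlier step, and because a 1.1-fold higher number from compound 3 to compound 1 (0.04 log units; within the scatter) was within the scatter, a similarly small step is expected, namely a 1.1-fold higher number from compound 2 to compound 4 (0.05 log units; within the scatter). On that basis compound 4 is estimated to give 70 ug/mL in this assay, with a likely range from 40 ug/mL to 125 ug/mL.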

Compound 4, half-maximal inhibitory concentration: 65 ug/mL
Compound 4: middle estimate off by 1.1-fold (0.03 log units), on the high side, and the stated range covers the measured number.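

On the core that carries the aminoamino group, furan-2-yl in place of thiophen-2-yl makes a step in this assay of a 1.0-fold higher number from compound 2 to compound 4 (0.01 log units; within the scatter), so the two values cannot be told apart. Set beside the same change on the other core, the two steps agree: the same change on two cores in this assay, a 1.1-fold higher number (0.04 log units; within the scatter) from compound 3 to compound 1 and a 1.0-fold higher number (0.01 log units; within the scatter) from compound 2 to compound 4, 1.1-fold (0.03 log units) apart, within the scatter of two such steps. Going by these compounds alone, this shows that on these two cores the exchange gives no step that can be told from the scatter, but it rests on only two pairs in one assay, and it does not show that the exchange would behave the same way on any further core or why the two steps agree.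

The compounds shown carry only thiophen-2-yl or furan-2-yl at this place, which leaves open what an amine, a carboxylic acid or a longer alkyl chain there would give in this assay. Also open, going by these compounds, is whether any change to the group that differs between the two cores, or to the cyano group, would give a step beyond the scatter.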